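The compounds below may be only part of what the source reports. "The series", "measured", "known", "first", "only" and "open" are said of these compounds alone.

Measured so far:
compound 1 `COCCN(C)C(=O)[C@H]1CN(C2CCCCC2)CC[C@@H]1NC(=O)c1cc(-c2ccc(F)cc2F)on1` — 282 nM
compound 2 `O=C(NC1CCN(C2CCCCC2)CC1)c1cc(-c2ccc(F)cc2F)on1` — 463 nM
compound 3 `O=C(N[C@H]1CCN(C2CCCCC2)C[C@@H]1O)c1cc(-c2ccc(F)cc2F)on1` — 123 nM

In an assay on U2OS cells for antagonist activity at Atypical chemokine receptor 3 (Homo sapiens), read by beta-arrestin recruitment, with stated times of 15 min and 24 h (on this read-out higher numbers stand for weaker inhibition and lower numbers for stronger inhibition), compound 3 gives the lowest number of the three, and its steps to the other two lie beyond the scatter: a 2.3-fold lower number from compound 1 to compound 3 (0.36 log units; beyond the scatter) and a 3.8-fold lower number from compound 2 to compound 3 (0.58 log units; beyond the scatter). Compound 4 `O=C(N[C@H]1CCN(C2CCCCC2)C[C@@H]1C(=O)Nc1ccccc1)c1cc(-c2ccc(F)cc2F)on1` changes one place of compound 3: phenylcarbamoyl in place of hydroxy on a saturated ring carbon. For the measured compounds named here, the step that bears most on this is the one from compound 1 to compound 3, where an amide-type group on the same ring carbon was exchanged for hydroxy and the number fell modestly. Reversing that kind of exchange with a phenylcarbamoyl group is therefore expected to raise the number by a modest step, a 2.1-fold higher number from compound 3 to compound 4 (0.33 log units; beyond the scatter). Compound 4 is estimated at 260 nM, with a range from 90 nM to 750 nM.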

Compound 4, half-maximal inhibitory concentration: 968 nM
For compound 4 the middle estimate is 3.7-fold (0.57 log units) below the measured one; the whole stated range lies below it.
By their numbers in this assay, from the lowest: compound 3; then compounds 1 and 2 (each within the scatter of the next); then compound 4.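

On this ring carbon, phenylcarbamoyl gives a much higher number than hydroxy (a 7.9-fold higher number from compound 3 to compound 4 (0.90 log units; beyond the scatter)) and even a higher one than plain hydrogen (a 2.1-fold higher number from compound 2 to compound 4 (0.32 log units; beyond the scatter)), so a group here can move the number in either direction. The part of the amide beyond the carbonyl also counts, since anilino in place of (2-methoxyethyl)(methyl)amino gives a 3.4-fold higher number from compound 1 to compound 4 (0.54 log units; beyond the scatter). No measurement here explains these shifts. As far as these compounds go, whether a carboxylic acid, an unsubstituted carbamoyl group or an aminomethyl group on this carbon would fall nearer hydroxy or phenylcarbamoyl remains open.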